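Inverting one stereocentre in compound 3

A few compounds are considered here, and "the series" means these few. Any claim that something is new, unique, unknown or untested is made for them only; others in the source may bear on it.

Compound 1 `NS(=O)(=O)c1ccccc1-c1ccc(C(=O)NC(CC(=O)Nc2ccc(Br)cn2)C(=O)O)cc1` gives 1 h
Compound 2 `NS(=O)(=O)c1ccccc1-c1ccc(C(=O)NC(CC(=O)Nc2ccc(Br)cn2)C(=O)N2CCCCC2)cc1` gives 1.35 h
Compound 3 `CN(C)Cc1ccccc1-c1ccc(C(=O)N[C@@H](CC(=O)Nc2ccc(Cl)cn2)C(=O)N2CCCCC2)cc1` gives 6.1 h

In an ADME assay (Rattus norvegicus) for pharmacokinetics (on this read-out higher numbers stand for a longer-lived compound and lower numbers for a shorter-lived compound), compound 3 at 6.1 h has the highest of the three numbers, and its gaps to both others lie beyond the scatter. Compound 4 `CN(C)Cc1ccccc1-c1ccc(C(=O)N[C@H](CC(=O)Nc2ccc(Cl)cn2)C(=O)N2CCCCC2)cc1` differs from compound 3 as follows the two compounds have the same atoms and bonds and differ only in configuration as drawn: 1 of 1 stereo elements differ; a stereocentre at a saturated chain carbon is drawn S in compound 3 and R in compound 4 and nothing else changes. The two compounds have the same atoms and bonds, so the difference lies only in how the groups at that one carbon are arranged in space.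

The measured data offer little guidance on such a change. Among the measured compounds shown here, the only step that alters a single place is a 1.4-fold higher number from compound 1 to compound 2 (0.13 log units; within the scatter) and it stays within the scatter. That step puts piperidin-1-yl in place of hydroxy on a carbonyl carbon, which is not a change of configuration, so it bears only indirectly. For the measured compounds named here, no measured pair tests a change of configuration.

The best anchor is therefore compound 3 with its 6.1 h as the starting point. The expected step is a 1.2-fold lower number from compound 3 to compound 4 (0.09 log units; within the scatter) and this is no larger than the scatter, with a slight downward lean. The range stays wide, since nothing measured constrains this change. For compound 4 the estimated half-life is 5 h with an expected range from 2 h to 11 h in this estimate.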

Compound 4, half-life: 1.18 h
The estimate for compound 4 lay 4.2-fold (0.63 log units) above the measured number, and the stated range ends above it.
By their numbers in this assay, from the lowest: compounds 1, 4 and 2 (each within the scatter of the next); then compound 3.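

In this assay the arrangement of groups at this one saturated chain carbon turns out to matter: the change gives a 5.2-fold lower number from compound 3 to compound 4 (0.71 log units; beyond the scatter) and so lies well clear of ordinary repeat variation. Among the compounds shown here, the only earlier single-place step, a 1.4-fold higher number from compound 1 to compound 2 (0.13 log units; within the scatter), showed no such separation, and it concerned a carbonyl substituent, so this is the first sign that the half-life responds to configuration at this position. The shift can be assigned to that single carbon alone, because no other part of the structure changes: the fact that compounds 3 and 4 differ only in the configuration as drawn

On these data alone, this rests on a single pair, with the piperidin-1-yl amide and the same dimethylamino-bearing side of the molecule in both compounds, and compounds 1 and 2 are drawn with no configuration at this carbon, so it remains open whether the drawn S form would keep its longer half-life in other settings. It is also unknown whether the same gap between the two arrangements would appear with a morpholine amide in place of the piperidin-1-yl amide, or with a longer chain at this carbon.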